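Swapping cyclohexyl for tert-butyl on the shared core

The source may report more compounds than this note shows. Statements on the series, on what has been measured and on what is new or still open speak of the compounds shown alone.

- compound 1 `CCNC(=O)Nc1sc2ccccc2c1C(=O)N1CCN(C2CCN(C(=O)C(C)C)CC2)CC1`: "not determined" (no result reported)
- compound 2 `CCNC(=O)Nc1sc2ccccc2c1C(=O)N1CCN(C2CCN(C(=O)OC)CC2)CC1`: "not determined" (no result reported)
- compound 3 `CCNC(=O)Nc1sc2ccccc2c1C(=O)N1CCN(C2CCN(C(=O)OC3CCCCC3)CC2)CC1`: 635 nM

Going by the values given here, in a functional assay on HepG2 cells (Homo sapiens) for inhibition, read by scintillation counting, with a stated time of 2 h (on this read-out higher numbers stand for weaker inhibition and lower numbers for stronger inhibition), compound 3 gives 635 nM, the only number among the three, so it cannot be ranked against the others. Compound 4 `CCNC(=O)Nc1sc2ccccc2c1C(=O)N1CCN(C2CCN(C(=O)OC(C)(C)C)CC2)CC1` keeps the shared core and changes one group: tert-butyl in place of cyclohexyl on an oxygen next to a carbonyl group. In words, tert-butyl stands in place of cyclohexyl on an oxygen next to a carbonyl group. Among the compounds with values here, no measured pair shows what such a swap does, so the expectation rests only on compound 3 at 635 nM, and no step beyond the usual scatter is expected in this assay. The expected change is a 1.3-fold higher number from compound 3 to compound 4 (0.10 log units; within the scatter). Compound 4 is estimated at 800 nM, with an expected range of 250 nM to 2500 nM.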

Compound 4, half-maximal inhibitory concentration: 79 nM
For compound 4 the middle estimate is 10-fold (1.01 log units) above the measured one, and the stated range ends above it.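

Going by these compounds alone, this is the first measured step at this place: on an oxygen next to a carbonyl group, tert-butyl in place of cyclohexyl gives an 8.0-fold lower number from compound 3 to compound 4 (0.91 log units; beyond the scatter) in this assay and lies beyond the usual scatter. The group on this oxygen therefore matters to the read-out, and in this single pair the ring-free tert-butyl gives stronger inhibition. No evidence at hand explains the step.

As far as these compounds go, whether a cyclopentyl or phenyl group on this oxygen would behave more like tert-butyl or cyclohexyl stays open. Compound 1 and compound 2 carry no number, so steps involving them cannot be read.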